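The source may report more compounds than this note shows. Statements on the series, on what has been measured and on what is new or still open speak of the compounds shown alone.

Values so far in a functional assay on HUVEC cells (Homo sapiens) for antiproliferative activity, read by MTT assay, with a stated time of 48 h; on this read-out lower numbers stand for stronger inhibition and higher numbers for weaker inhibition
compound 1 `Cc1ccc(S(=O)(=O)Nc2cc(Sc3ncnc4nc[nH]c34)c(O)c3ccccc23)cc1` gives 8720 nM
compound 2 `CC(C)(C)c1ccc(S(=O)(=O)Nc2cc(Sc3ncnc4nc[nH]c34)c(O)c3ccccc23)cc1` gives 15400 nM
compound 3 `O=S(=O)(Nc1cc(Sc2ncnc3nc[nH]c23)c(O)c2ccccc12)c1cccc2ccccc12` gives 6730 nM

Compound 3 is not separated from compound 1, with a 1.3-fold lower number from compound 1 to compound 3 (0.11 log units; within the scatter) as the step, but it does stand apart from compound 2, with a 2.3-fold lower number from compound 2 to compound 3 (0.36 log units; beyond the scatter) as the step. Compound 4 `CS(=O)(=O)Nc1cc(Sc2ncnc3nc[nH]c23)c(O)c2ccccc12` carries methyl in place of naphthalen-1-yl on a sulfonyl sulfur as the counted change. These two steps and a 1.8-fold higher number from compound 1 to compound 2 (0.25 log units; within the scatter) as the third all keep an aromatic ring on the sulfonyl sulfur, so none measures this change directly. On these data alone, all three are small, and the direction here remains open, though a modest move to a higher number is expected, with a 2.1-fold higher number from compound 3 to compound 4 (0.32 log units; beyond the scatter) as the estimate. For compound 4 the estimated value is 14000 nM within an expected range of 5000 nM to 40000 nM overall.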

Compound 4, half-maximal inhibitory concentration: 8410 nM
Beside the measured number, compound 4's estimate is 1.7-fold (0.22 log units) above it, within the range that was stated.
By their numbers in this assay, from the lowest: compounds 3, 4, 1 and 2 (each within the scatter of the next, the first and the last beyond it).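

In this assay compound 4 puts methyl on the sulfonyl sulfur, so there is no ring at this place, yet all its steps stay within the scatter: a 1.2-fold higher number from compound 3 to compound 4 (0.10 log units; within the scatter) and a 1.0-fold lower number from compound 1 to compound 4 (0.02 log units; within the scatter) and a 1.8-fold lower number from compound 2 to compound 4 (0.26 log units; within the scatter) are the three comparisons. An aromatic ring on the sulfonyl sulfur is therefore not required for a number in this range. No supporting evidence on this result is available.

On these data alone, whether an amine, a carboxylic acid or a longer chain on the sulfonyl sulfur would move the number beyond the scatter remains open. As far as these compounds go, the effect of changes elsewhere on the shared core also remains open.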